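The source may report more compounds than this note shows. Statements on the series, on what has been measured and on what is new or still open speak of the compounds shown alone.

Measured so far:
- compound 1, `COc1cc(C)cc(-c2c(-c3ccnc(-c4ccc(C(C)=O)cc4)c3)cnn2CC#N)c1`: 88%
- compound 2, `COc1cc(C)cc(-c2nn(CC#N)cc2-c2ccnc(-c3ccc(N(C)C)cc3)c2)c1`: 90%
- compound 3, `Cc1cc(O)cc(-c2nn(CC#N)cc2-c2ccnc(-c3ccc(N(C)C)cc3)c2)c1`: 90%

In a functional assay on SW-620 cells (Homo sapiens) for cytotoxicity, read by sulforhodamine B assay, with a stated time of 48 h, tested at 0.01 uM (on this read-out higher numbers stand for a weaker effect at the one concentration tested and lower numbers for a stronger effect), compound 1 gives 88%, the lowest of the three numbers, but the other two lie within the usual scatter of it, so nothing separates them. Among the compounds with values here, the only measured step, no change at the digits printed from compound 2 to compound 3 (within the scatter), shows that a change on the opposite end of the molecule leaves the read-out where it was.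

Compound 4, `COc1cc(C)cc(-c2c(-c3ccnc(-c4ccc(N(C)C)cc4)c3)cnn2CC#N)c1`, is reached from compound 1 by the change (dimethylamino in place of acetyl on an aromatic carbon). Within the data shown here, no measured step covers this exchange. Compounds 2 and 3 already carry the dimethylamino group, and in this assay compound 2 gives 90%, a number within the scatter of compound 1. With nothing pointing either way, the step of a number 2 percentage points higher from compound 1 to compound 4 (within the scatter) is expected to stay within the scatter. The estimate for compound 4 in this assay is therefore 90%, with a range from 80% to 100%.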

Compound 4, a percentage reported as activity, at one concentration (the size of the read-out at that concentration, not a potency): 69%
The estimate for compound 4 lay 21 percentage points above the measured number; the whole stated range lies above it.
By their numbers in this assay, from the lowest: compound 4; then compounds 1, 2 and 3 (each within the scatter of the next).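

The exchange of 4-acetylphenyl for 4-(dimethylamino)phenyl in this assay gives a number 19 percentage points lower from compound 1 to compound 4 (beyond the scatter) and so marks this place, on a six-membered aromatic ring of carbon only and para to a large group, as one where the read-out can respond to a change. The leaving and entering groups match in heavy atoms, hydrogen-bond donors and hydrogen-bond acceptors, so these counts do not separate compound 1 from compound 4. No measurement shown here explains why this exchange moves the number.

The compounds shown leave open how a primary amine, a carboxylic acid or a longer chain such as diethylamino would read at this same place. They also leave open whether the step would hold at other concentrations, since this is a single-concentration read-out and not a potency.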